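Adding a dimethylamino tail to compound 3

The source may hold more compounds than are shown below. What is called first, only, known or untested is meant among the compounds shown, and "the series" means these compounds.

Of the compounds shown here, three that share one core have been tested in a functional assay on HeLa cells (Homo sapiens) for cytotoxicity, read by neutral red uptake, with a stated time of 3 days; on this read-out lower numbers stand for stronger inhibition and higher numbers for weaker inhibition. Compound 1 `Nc1ccc(-c2cc(=O)c3c(N)c(F)c(O)c(F)c3o2)cc1F` reports only a limit, > 100000 nM, in this assay. Compound 2 `CN(C)c1c(F)c(N)c2c(=O)cc(-c3ccc(N)c(F)c3)oc2c1F` likewise reports only a limit, > 100000 nM, in this assay. Going by the values given here, compound 3 `CCCOCc1c(F)c(N)c2c(=O)cc(-c3ccc(N)c(F)c3)oc2c1F` is the single member with an actual number: in this assay compound 3 gives 78000 nM. The picture is dominated by the limit of > 100000 nM in this assay, at which 2 of the 3 values shown sit, and the two readable steps, an at least 1.2-fold lower number from compound 1 to compound 3 (0.10 log units; that floor lies within the scatter) and an at least 1.2-fold lower number from compound 2 to compound 3 (0.10 log units; that floor lies within the scatter), have floors that lie within the usual scatter, so no real movement between these compounds can be read. The step that the two limits leave unreadable from compound 1 to compound 2 cannot be read at all.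

Compound 4 `CN(C)CCCOCc1c(F)c(N)c2c(=O)cc(-c3ccc(N)c(F)c3)oc2c1F` is compound 3 with one change: dimethylamino in place of hydrogen on a saturated chain carbon, three bonds along the chain from an oxygen on a saturated carbon. Among the compounds with values here, no measured step places a dimethylamino on a saturated chain, and the step from compound 1 to compound 2, where a dimethylamino replaced a hydroxy on an aromatic carbon, gave no readable size, so there is no measured ground for expecting a shift beyond the scatter. The expected step is therefore a 1.0-fold higher number from compound 3 to compound 4 (0.01 log units; within the scatter). Compound 4 is estimated to give 80000 nM in this assay, within 30000 nM to 200000 nM, with a fair chance that only a limit is reported.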

Compound 4, half-maximal inhibitory concentration: 12000 nM
Compound 4: middle estimate off by 6.7-fold (0.82 log units), on the high side; the whole stated range lies above it.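

In this assay, going from propyl to 3-(dimethylamino)propyl gives a 6.5-fold lower number from compound 3 to compound 4 (0.81 log units; beyond the scatter). This is the first step among these compounds with an actual number at both ends that lies beyond the scatter, so this chain can shift the read-out even though the shared core stays the same and the only change is on a saturated chain carbon, three bonds along the chain from an oxygen on a saturated carbon. Against the two compounds with limits, the full side chain gives an at least 8.3-fold lower number from compound 2 to compound 4 (0.92 log units; beyond the scatter) and an at least 8.3-fold lower number from compound 1 to compound 4 (0.92 log units; beyond the scatter), and these sizes are only floors because those two values are limits: the limit of > 100000 nM in this assay, at which 2 of the 4 values shown sit.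

The compounds shown leave open whether the step belongs to the amine or simply to the added atoms, a question that a hydroxy or methoxy on the same chain carbon could help to settle. A longer chain ending in dimethylamino, or a piperidine in its place, would show whether the size of the step depends on the length of the chain or on the form of the amine.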